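Cytotoxicity notes: a second ring nitrogen at the aryl position

The source may report more compounds than this note shows. Statements on the series, on what has been measured and on what is new or still open speak of the compounds shown alone.

Within the data shown here, compound 3 `Cc1cc(C#N)cc(C)c1Oc1nc(Nc2ccc(C#N)cc2)ncc1-c1ccccc1` gives 31800 nM in an ADME assay on MT4 cells (Homo sapiens) for cytotoxicity, read by MTT assay, with a stated time of 5 days (a higher number here means that more compound is tolerated, a lower number that less compound is tolerated), the highest of the three numbers so far. Compound 1 `Cc1cc(C#N)cc(C)c1Oc1nc(Nc2ccc(C#N)cc2)ncc1-c1ccncc1` gives 28000 nM and compound 2 `Cc1cc(C#N)cc(C)c1Oc1nc(Nc2ccc(C#N)cc2)ncc1-c1ccc(N)cc1` gives 310 nM; the step of a 1.1-fold higher number from compound 1 to compound 3 (0.06 log units; within the scatter) lies within the scatter, whereas a 100-fold higher number from compound 2 to compound 3 (2.01 log units; beyond the scatter) is large. Compound 4 `Cc1cc(C#N)cc(C)c1Oc1nc(Nc2ccc(C#N)cc2)ncc1-c1cncnc1` differs from compound 3 by pyrimidin-5-yl in place of phenyl on an aromatic carbon. Among the measured compounds shown here, the only step that bears on this change is the exchange of pyridin-4-yl for phenyl, a 1.1-fold higher number from compound 1 to compound 3 (0.06 log units; within the scatter), which moved nothing beyond the scatter; the large step of a 90-fold lower number from compound 1 to compound 2 (1.96 log units; beyond the scatter) involved an amino group rather than a ring nitrogen and does not apply here. A step of a 1.1-fold lower number from compound 3 to compound 4 (0.03 log units; within the scatter) is therefore expected, none beyond the scatter. Compound 4 is estimated at 30000 nM, within 12000 nM to 75000 nM.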

Compound 4, half-maximal cytotoxic concentration: > 298000 nM
Compound 4 ended at the assay's limit (the forecaster's own chance of this, stated with the estimate: 15%); middle value at least 9.9-fold (0.99 log units) from the limit.
By their numbers in this assay, from the lowest: compound 2; then compounds 1 and 3 (each within the scatter of the next). At a limit, above all of these: compound 4.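

In this assay compound 4 stands at a limit of the assay, not at a number: the limit of > 298000 nM in this assay, at which 1 of the 4 values shown sits. At this aromatic carbon, pyrimidin-5-yl separates from both earlier rings, with an at least 9.3-fold higher number from compound 3 to compound 4 (0.97 log units; beyond the scatter) and an at least 10-fold higher number from compound 1 to compound 4 (1.02 log units; beyond the scatter), although pyridin-4-yl and phenyl sit within the scatter of each other. The distance from the 4-aminophenyl ring is wider still, with an at least 960-fold higher number from compound 2 to compound 4 (2.98 log units; beyond the scatter).

Open, going by these compounds, is whether the second ring nitrogen alone carries this step, or whether its placing matters too. Also open, on these data alone, is how a pyridin-3-yl ring or a carboxylic acid on the phenyl ring would read here.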